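Chloro in place of trifluoromethyl on the benzyl arm

The source may hold more compounds than are shown below. What is called first, only, known or untested is meant among the compounds shown, and "the series" means these compounds.

Measured so far:
- compound 1 `O=S(=O)(NCCCNCc1ccc(C(F)(F)F)cc1)c1cc(C(F)(F)F)cc(C(F)(F)F)c1` — in a functional assay on HPAC cells (Homo sapiens) for inhibition, read by MTT assay, with a stated time of 72 h (a lower number here means a stronger inhibitor of growth, a higher number a weaker inhibitor of growth), compound 1 gives 2700 nM
- compound 2 `CC(C)(C)c1ccc(CNCCNS(=O)(=O)c2cc(C(F)(F)F)cc(C(F)(F)F)c2)cc1` — compound 2 gives 14000 nM

Compound 1 holds the lowest of the two numbers; compound 2 gives the higher one, and the gap between the two lies beyond the usual scatter. For the measured compounds named here, no step between measured compounds differs in a single place, so there is no measured pairwise step to lean on.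

Compound 3 `O=S(=O)(NCCCNCc1ccc(Cl)cc1)c1cc(C(F)(F)F)cc(C(F)(F)F)c1` is the next compound, not yet measured. It keeps the shared core of compound 1 and differs at one position only: chloro in place of trifluoromethyl on an aromatic carbon. The change sits on an aromatic carbon of a six-membered aromatic ring of carbon only, on the benzyl arm. Nothing in the two measured compounds isolates the contribution of this group, so the expected step is small and uncertain: the estimate for compound 3 in this assay is 3500 nM, within 1500 nM to 9000 nM. The step this implies, a 1.3-fold higher number from compound 1 to compound 3 (0.11 log units; within the scatter), is expected to stay within the scatter or to weaken inhibition only slightly.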

Compound 3, concentration for 50% growth inhibition: 2800 nM
Compound 3: the middle estimate sits 1.3-fold (0.10 log units) above what was measured; low and high end bracket the measured number.
By their numbers in this assay, from the lowest: compounds 1 and 3 (each within the scatter of the next); then compound 2.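

In this assay, chloro in place of trifluoromethyl on the benzyl arm gives a 1.0-fold higher number from compound 1 to compound 3 (0.02 log units; within the scatter), so 4-(trifluoromethyl)benzyl and 4-chlorobenzyl cannot be told apart on the core of compound 1 in this read-out. For the compounds shown here, this is the first step that differs in one place only, and it shows that a substituent of 4 heavy atoms (1 carbon, 3 fluorine) on this aromatic carbon can be exchanged for a single chlorine without a difference beyond the scatter. No measurement bears on why the two groups read alike, and the result stands as an observation for this one pair.

As far as these compounds go, whether this holds for a different kind of group on the same aromatic carbon, such as a carboxylic acid, an amine or a plain hydrogen, stays open, as does the effect of a longer chain on the core of compound 1. Compound 2 differs from compound 1 in the chain as well as on the benzyl arm, so the shown compounds do not assign its gap to either place, and the tert-butyl group remains unresolved.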